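Phenyl in place of the hydroxyethylpiperidine on the quinoline amide

The source may report more compounds than this note shows. Statements on the series, on what has been measured and on what is new or still open speak of the compounds shown alone.

Compound 3 `CC(C)(C)OC(=O)NC[C@H]1CC[C@H](CNC(=O)c2cc(N3CCC(CCO)CC3)nc3ccccc23)CC1` gives 4.5 in a physicochemical assay for lipophilicity (on this read-out lower numbers stand for lower lipophilicity and higher numbers for higher lipophilicity), the second highest of three numbers. Compound 1 `CC(C)(C)OC(=O)NC[C@H]1CC[C@H](CNC(=O)c2cc(-c3ccccc3)nc3[nH]ccc23)CC1` gives 4.7, within the scatter of compound 3, while compound 2 `CC(C)(C)OC(=O)NC[C@H]1CC[C@H](CNC(=O)c2cc(N3CCC(CCN4CC(O)C4)CC3)nc3ccccc23)CC1` gives 3.6, the lowest. Going by the values given here, the only measured step is a number 0.90 log units higher from compound 2 to compound 3 (beyond the scatter). Compound 4 `CC(C)(C)OC(=O)NC[C@H]1CC[C@H](CNC(=O)c2cc(-c3ccccc3)nc3ccccc23)CC1` differs from compound 3 by phenyl in place of 4-(2-hydroxyethyl)piperidin-1-yl on an aromatic carbon. Among the compounds with values here, no measured pair matches this change; the step from compound 2 to compound 3 concerns a hydroxy group on the chain and offers only a loose guide, and compound 1 carries the same phenyl on a different core. The loss of the hydrogen-bond donor and both acceptors leads to an expected increase of a number 0.80 log units higher from compound 3 to compound 4 (beyond the scatter), so compound 4 is estimated at 5.3, between 4.7 and 5.9.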

Compound 4, distribution coefficient: 5.9
The estimate for compound 4 lay 0.60 log units below the measured number; measured number inside the range.
By their numbers in this assay, from the lowest: compound 2; then compounds 3 and 1 (each within the scatter of the next); then compound 4.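

At the aromatic carbon next to the ring nitrogen, phenyl in place of 4-(2-hydroxyethyl)piperidin-1-yl gives, in this assay, a number 1.40 log units higher from compound 3 to compound 4 (beyond the scatter). The earlier step, a number 0.90 log units higher from compound 2 to compound 3 (beyond the scatter), altered only the end of the chain, whereas this one exchanges the whole group, and the printed step is the larger of the two. No measurement available here accounts for the size of this step. The compounds shown leave open how much of the step belongs to the hydroxyethyl chain and how much to the ring itself. Plain piperidin-1-yl or morpholine on the same aromatic carbon would separate the two.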